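A few compounds are considered here, and "the series" means these few. Any claim that something is new, unique, unknown or untested is made for them only; others in the source may bear on it.

Measured in an assay on CHO cells for displacement of a labelled ligand from adenosine receptor A1 (Homo sapiens), read by scintillation counting, with a stated time of 120 min, tested at 1 uM; on this read-out higher numbers stand for more inhibition at the one concentration tested (going by the name of the read-out) and lower numbers for less inhibition:
compound 1, `COc1ccc(-c2nc3cn(C)nc3c(=O)[nH]2)cc1`, gives 2%
compound 2, `COc1ccc(-c2nc(N)c3nn(-c4ccccc4)cc3n2)cc1`, gives 33%
compound 3, `COc1ccc(-c2nc(N)c3nn(-c4ccc(OC)cc4)cc3n2)cc1`, gives 1%

Compound 3 and compound 2 share one core; the change between them is hydrogen in place of methoxy on an aromatic carbon, and it made a number 32 percentage points higher from compound 3 to compound 2 (beyond the scatter). Compound 1 sits on a different core, and the difference between the two cores is not broken down here. Compound 1 and compound 3 lie within the scatter of each other, both well under compound 2.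

Compound 4, `Cn1cc2nc(-c3ccccc3)[nH]c(=O)c2n1`, is not yet measured. It differs from compound 1 by hydrogen in place of methoxy on an aromatic carbon, the same change as from compound 3 to compound 2. If that step carried over to the core of compound 1, compound 4 would be expected to rise by about a number 18 percentage points higher from compound 1 to compound 4 (beyond the scatter) in this assay; this rests on one step only, seen on another core, so the range is wide. Compound 4 is therefore estimated at 20%, between 0% and 42%.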

Compound 4, a percentage reported as inhibition, at one concentration (the size of the read-out at that concentration, not a potency): 1%
Beside the measured number, compound 4's estimate is 19 percentage points above it, and the stated range covers the measured number.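

In this assay, the step on the core of compound 1 is a number 1 percentage points lower from compound 1 to compound 4 (within the scatter), so no gain appears there. Hydrogen in place of methoxy on an aromatic carbon therefore does not carry over from one core to the other with the same size: the same change on two cores in this assay, a number 32 percentage points higher (beyond the scatter) from compound 3 to compound 2 and a number 1 percentage points lower (within the scatter) from compound 1 to compound 4, 33 percentage points apart, beyond the scatter of two such steps. For the compounds shown here, with only one pair on each core, tested at one concentration, this shows no general rule for either core and gives no reason for the difference.

Still open, as far as these compounds go, is whether a group other than methoxy at that place, such as chlorine or hydroxyl, would behave alike on the two cores. Also open, from the compounds shown here alone, is whether a longer chain in place of the methyl on the core of compound 1 would alter the read-out.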